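The compounds below may be only part of what the source reports. "The series", "measured", "known", "first", "only" and "open" are said of these compounds alone.

Measured compounds:
compound 1 `Oc1ccc(-c2cc(-c3cccs3)cc(-c3ccc(O)cc3)n2)cc1`: 86.3%
compound 2 `Oc1ccc(-c2cc(-c3ccsc3)cc(-c3ccc(O)cc3)n2)cc1`: 61.7%
compound 3 `Oc1ccc(-c2cc(-c3ccoc3)cc(-c3cccc(O)c3)n2)cc1`: 37.4%

All three were tested in an assay on isolated protein for inhibition of DNA topoisomerase 1 (Homo sapiens), with a stated time of 30 min, tested at 100 uM; a lower number here means a weaker effect, a higher number a stronger effect of the compound at the concentration tested. In this assay compound 1 gives 86.3%, compound 2 gives 61.7%, and compound 3 gives 37.4%. Compound 3 therefore stands lowest of the three, with compound 2 nearest to it and compound 1 furthest away, both gaps being beyond the usual scatter. Going by the values given here, the one step between measured compounds that differ in a single place is the exchange of the five-membered ring partner: a number 24.6 percentage points lower from compound 1 to compound 2 (beyond the scatter).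

Compound 4 `Oc1ccc(-c2cc(-c3ccoc3)cc(-c3ccc(O)cc3)n2)cc1` is not yet measured. It is formed from compound 3 by a change that keeps every atom and only rearranges one group: 4-hydroxyphenyl in place of 3-hydroxyphenyl on an aromatic carbon. Among the compounds with values here, no measured step speaks to this particular change, since the only step on record concerns the thiophene ring and not the hydroxyphenyl group. What can be said is that compound 1 and compound 2, which both carry the 4-hydroxyphenyl group at this place, sit higher in this assay than compound 3, though they differ from compound 3 in a second place as well. On that basis a modest rise is expected for compound 4, of about a number 12.6 percentage points higher from compound 3 to compound 4 (beyond the scatter), though a step within the scatter would not be surprising. The estimate for compound 4 in this assay is 50%, with a range from 30% to 70%.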

Compound 4, a percentage reported as inhibition, at one concentration (the size of the read-out at that concentration, not a potency): 74.9%
Estimate against measurement, compound 4: 24.9 percentage points below; measured number above the stated range.
By their numbers in this assay, from the lowest: compound 3; then compound 2; then compound 4; then compound 1.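

In this assay, going by these compounds alone, exchanging 3-hydroxyphenyl for 4-hydroxyphenyl on the aromatic carbon next to the ring nitrogen keeps every atom and only rearranges the group, yet it gives a number 37.5 percentage points higher from compound 3 to compound 4 (beyond the scatter), the first direct reading of this change. With 4-hydroxyphenyl now fixed at this place, the furan-3-yl group can also be compared directly with both sulfur-containing rings: furan-3-yl in place of thiophen-3-yl gives a number 13.2 percentage points higher from compound 2 to compound 4 (beyond the scatter), while furan-3-yl in place of thiophen-2-yl gives a number 11.4 percentage points lower from compound 1 to compound 4 (beyond the scatter). Among the compounds shown, the largest single step therefore comes from relocating the hydroxyl group on this phenyl ring, and exchanging one five-membered ring for another produces smaller steps in either direction.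

The compounds shown leave open whether an amine or a methoxy group could stand in for the hydroxyl group on this phenyl ring, and whether a furan-2-yl group would follow the thiophen-2-yl group in giving a higher number than its 3-yl partner. Nothing available explains why this rearrangement of the hydroxyphenyl group changes the number so strongly.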